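This account rests on a few compounds, and the source may have more. Where it says the series, first, only, none or still open, it means among the compounds named here.

Three compounds share one core and differ only in the group attached to the carbon that carries a double bond to nitrogen. In a functional assay on MGC-803 cells (Homo sapiens) for inhibition, read by MTT assay (on this read-out higher numbers stand for weaker inhibition and lower numbers for stronger inhibition), compound 1 `Cc1c(C(=O)N/N=C\c2c(O)cccc2F)oc2cccc(O)c12` gives 10800 nM, compound 2 `Cc1ccc(O)c(/C=N\NC(=O)c2oc3cccc(O)c3c2C)c1` gives 5990 nM, and compound 3 `Cc1c(C(=O)N/N=C\c2ccc(Br)cc2O)oc2cccc(O)c12` gives 5460 nM. Every step among them stays within the scatter: a 1.8-fold lower number from compound 1 to compound 2 (0.26 log units; within the scatter), a 2.0-fold lower number from compound 1 to compound 3 (0.30 log units; within the scatter) and a 1.1-fold lower number from compound 2 to compound 3 (0.04 log units; within the scatter). Compound 4 `Cc1c(C(=O)N/N=C\c2cc(Cl)ccc2O)oc2cccc(O)c12` repeats this kind of exchange: 5-chloro-2-hydroxyphenyl in place of 4-bromo-2-hydroxyphenyl on a carbon with a double bond to nitrogen. Since the three earlier swaps at this place moved this assay by no more than the scatter, no step beyond the scatter is expected here either, so the estimated step is a 1.0-fold higher number from compound 3 to compound 4 (0.00 log units; within the scatter). Compound 4 is therefore expected to give about 5500 nM, with a plausible range from 2500 nM to 12000 nM.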

Compound 4, half-maximal inhibitory concentration: 4160 nM
Compound 4: middle estimate off by 1.3-fold (0.12 log units), on the high side; measured number inside the range.
By their numbers in this assay, from the lowest: compounds 4, 3, 2 and 1 (each within the scatter of the next, the first and the last beyond it).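

Going by these compounds alone, exchanging 2-fluoro-6-hydroxyphenyl for 5-chloro-2-hydroxyphenyl gives the first step at this position that lies beyond the scatter in this assay (a 2.6-fold lower number from compound 1 to compound 4 (0.41 log units; beyond the scatter)), though it is modest. Compound 4 stays within the scatter of the other two, both for the halogen and ring-position exchange (a 1.3-fold lower number from compound 3 to compound 4 (0.12 log units; within the scatter)) and for chloro in place of methyl (a 1.4-fold lower number from compound 2 to compound 4 (0.16 log units; within the scatter)). Within the data shown here, nothing available explains the one larger step.

Every group shown pairs a hydroxyl with a halogen or methyl on the phenyl ring. On these data alone, how an amine or a carboxylic acid there would behave remains open.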